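Extending the side chain from propyl to butyl

This account rests on a few compounds, and the source may have more. Where it says the series, first, only, none or still open, it means among the compounds named here.

In a functional assay on the whole organism (Abdomen, strain Swiss) for inhibition, with Mus musculus as the target, with stated times of 30 min, 10 min and 5 min, at a dose of 10 mg/kg by the oral route (on this read-out lower numbers stand for a weaker effect and higher numbers for a stronger effect at the one dose given), compound 1 `CCCCC(=O)c1c(C)nn(CCCN2CCN(c3ccc(C)cc3)CC2)c(=O)c1N` gives 8%. Compound 2 `C=Cc1c(CC)nn(CCCN2CCN(c3ccc(C)cc3)CC2)c(=O)c1N` gives 0% in this assay, and compound 3 `C=Cc1c(CCC)nn(CCCN2CCN(c3ccc(C)cc3)CC2)c(=O)c1N` gives 3%. Compound 3 thus holds the second highest of the three numbers shown; its nearest neighbour is compound 2 and its furthest is compound 1, and both of those gaps lie within the usual scatter of this kind of measurement. Compound 4 `C=Cc1c(CCCC)nn(CCCN2CCN(c3ccc(C)cc3)CC2)c(=O)c1N` has not yet been measured in this assay. It differs from compound 3 by methyl in place of hydrogen on a saturated chain carbon, three bonds along the chain from an aromatic carbon. Among the compounds with values here, the one measured step that bears on this change is the same kind of change one bond closer to the ring, a number 3 percentage points higher from compound 2 to compound 3 (within the scatter), which did not leave the scatter. On that basis no step beyond the scatter is expected from compound 3 to compound 4, the expected step being a number 1 percentage points higher from compound 3 to compound 4 (within the scatter). Compound 4 is therefore estimated at 4%, with a range from 0% to 12%.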

Compound 4, a percentage reported as inhibition, in the whole organism at one dose (the size of the read-out at that dose, not a potency): 0%
Compound 4: middle estimate off by 4 percentage points, on the high side; the range from low to high includes it.
By their numbers in this assay, from the lowest: compounds 2, 4, 3 and 1 (each within the scatter of the next).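

In this assay, going from propyl to butyl gives a number 3 percentage points lower from compound 3 to compound 4 (within the scatter) and so does not extend the small rise seen one bond closer to the ring. With ethyl in place of hydrogen on the saturated chain carbon two bonds along the chain from an aromatic carbon, the result is no change at the digits printed from compound 2 to compound 4 (within the scatter), so ethyl, propyl and butyl at this position cannot be told apart among compound 2, compound 3 and compound 4 at the one dose given. No measurement at hand bears on the reason for this result.

As far as these compounds go, it remains open whether a chain longer than butyl, a branched chain such as isobutyl, or an amine or a carboxylic acid at this position would give a step beyond the scatter. Also open, from the compounds shown here alone, is whether these three chains would separate at another dose.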